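A few compounds are considered here, and "the series" means these few. Any claim that something is new, unique, unknown or untested is made for them only; others in the source may bear on it.

Compound 1 `O=C1COc2ccc(-c3cccc(NS(=O)(=O)c4ccc(F)cc4)c3)cc2N1`: > 40000 nM, a limit
Compound 2 `O=C1COc2ccc(-c3cccc(NS(=O)(=O)c4ccc(F)cc4)c3)cc2N1c1ccc(Cl)cc1`: 23900 nM
Compound 3 `O=C1COc2ccc(-c3cccc(NS(=O)(=O)c4ccc(F)cc4)c3)cc2N1C1CC1`: > 40000 nM, a limit

In a functional assay on HCT-116 cells (Homo sapiens) for antiproliferative activity, read by MTT assay, with a stated time of 72 h (on this read-out lower numbers stand for stronger inhibition and higher numbers for weaker inhibition), compound 3 gives only > 40000 nM, which is a limit. It stands at the limit of > 40000 nM in this assay, at which 2 of the 3 values shown sit, so it has no number of its own.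

The change now followed is 4-methoxyphenyl in place of cyclopropyl on an amide-type nitrogen in a ring, and it leads to compound 4 `COc1ccc(N2C(=O)COc3ccc(-c4cccc(NS(=O)(=O)c5ccc(F)cc5)c4)cc32)cc1`. Among the measured compounds shown here, three measured steps bear on it. The nearest is an at least 1.6-fold higher number from compound 2 to compound 3 (0.22 log units; that floor lies within the scatter), and an at least 1.6-fold lower number from compound 1 to compound 2 (0.22 log units; that floor lies within the scatter) points the same way. The third is a step that the two limits leave unreadable from compound 1 to compound 3.

Compound 2 alone has a number, 23900 nM, and it carries 4-chlorophenyl on the same amide-type nitrogen. Compound 4 likewise carries a six-membered aromatic ring there, so a value near that of compound 2 is expected, although a single compound is thin support. The expected result is an at least 1.6-fold lower number from compound 3 to compound 4 (0.20 log units; that floor lies within the scatter), a small shift towards a lower number in this assay, and another limit remains quite possible. For compound 4 the estimated value is 25000 nM, with an expected range from 12000 nM to 40000 nM.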

Compound 4, half-maximal inhibitory concentration: 28300 nM
For compound 4 the middle estimate is 1.1-fold (0.05 log units) below the measured one, and the stated range covers the measured number.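

The 4-chlorophenyl and 4-methoxyphenyl groups on the amide-type nitrogen in a ring read alike in this assay: a 1.2-fold higher number from compound 2 to compound 4 (0.07 log units; within the scatter). A measured number at this position thus no longer rests on a single compound, as both groups with a six-membered aromatic ring give one, while the other two compounds each show only a limit: the limit of > 40000 nM in this assay, at which 2 of the 4 values shown sit. Against those limits the gaps remain floors, an at least 1.4-fold lower number from compound 3 to compound 4 (0.15 log units; that floor lies within the scatter) and an at least 1.4-fold lower number from compound 1 to compound 4 (0.15 log units; that floor lies within the scatter), so the true size of the shift cannot be read.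

As far as these compounds go, it remains open whether an unsubstituted phenyl, a benzyl group or a longer chain ending in an amine on this nitrogen would give a number like these two. Also open, from the compounds shown here alone, is whether the agreement would hold with a carboxylic acid in place of chloro or methoxy on the aromatic carbon.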